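The source may hold more compounds than are shown below. What is called first, only, known or untested is meant among the compounds shown, and "the series" means these compounds.

Compound 2 `CCCS(=O)(=O)Nc1ccc(F)c(C(=O)c2n[nH]c3ncc(-c4ccc(C(C)(C)C)cc4)cc23)c1F` gives 46% in an assay for binding affinity to dual specificity mitogen-activated protein kinase kinase 4 (Homo sapiens), read by KINOMEscan, tested at 100 nM (a higher number here means a weaker effect of the compound at the concentration tested, a lower number a stronger effect), the highest of the two numbers shown; its nearest neighbour is compound 1 `CCCS(=O)(=O)Nc1ccc(F)c(C(=O)c2n[nH]c3ncc(-c4ccc(F)cc4)cc23)c1F`, which gives 2.1%. Compound 3 `CCCS(=O)(=O)Nc1ccc(F)c(C(=O)c2n[nH]c3ncc(-c4cccc(C(F)(F)F)c4)cc23)c1F` differs from compound 2 by 3-(trifluoromethyl)phenyl in place of 4-(tert-butyl)phenyl on an aromatic carbon. Among the measured compounds shown here, the only measured step that bears on this change is a number 43.9 percentage points higher from compound 1 to compound 2 (beyond the scatter). That step is a large rise, and the tert-butyl now leaves again. For the measured compounds named here, the number is therefore expected to fall back toward compound 1, as the step of a number 31 percentage points lower from compound 2 to compound 3 (beyond the scatter), though the entering trifluoromethyl has no precedent here. Compound 3 is estimated at 15%, within a range of 2% to 50%.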

Compound 3, a percentage reported as activity, at one concentration (the size of the read-out at that concentration, not a potency): 57%
For compound 3 the middle estimate is 42 percentage points below the measured one; measured number above the stated range.
By their numbers in this assay, from the lowest: compound 1; then compound 2; then compound 3.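

Replacing 4-(tert-butyl)phenyl with 3-(trifluoromethyl)phenyl on this aromatic carbon does not bring back the low number of compound 1; instead it gives a number 11 percentage points higher from compound 2 to compound 3 (beyond the scatter), so the weakening is not tied to the tert-butyl alone. Against 4-fluorophenyl, the same group gives a number 54.9 percentage points higher from compound 1 to compound 3 (beyond the scatter), leaving 4-fluorophenyl as the only one of the three groups with a strong effect at the concentration tested. Nothing available explains this difference. Still open, going by these compounds, is how 3-fluorophenyl, 4-(trifluoromethyl)phenyl or an amine on the phenyl ring would read here, which could separate the effect of the group from that of its ring position.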